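Swapping Propyl for Phenyl in Compound 2

The compounds below may be only part of what the source reports. "The series", "measured", "known", "first", "only" and "open" are said of these compounds alone.

In an in vivo ADME assay on the whole organism (Cavia porcellus) (on this read-out higher numbers stand for a longer-lived compound and lower numbers for a shorter-lived compound), compound 2 `CCCCCC(NC(=O)c1ccc(C(=N)N)cc1)C(C)(C)C(=O)N1CCC(CC(=O)O)CC1` gives 0.517 h and compound 1 `CCCC(NC(=O)c1ccc(C(=N)N)cc1)C(C)(C)C(=O)N1CCC(CC(=O)O)CC1` gives 0.9 h with the two lying within the scatter of each other. Compound 3 `CC(C)(C(=O)N1CCC(CC(=O)O)CC1)C(CCc1ccccc1)NC(=O)c1ccc(C(=N)N)cc1` differs from compound 2 by one change (phenyl in place of propyl on a saturated chain carbon, three bonds along the chain from an amide-type nitrogen) with phenyl in place of propyl on a saturated chain carbon, three bonds along the chain from an amide-type nitrogen. Among the compounds with values here, the only measured step on this chain is a 1.7-fold lower number from compound 1 to compound 2 (0.24 log units; within the scatter) and it stays within the scatter. The estimated step is likewise small (a 1.2-fold higher number from compound 2 to compound 3 (0.06 log units; within the scatter)) and none beyond the scatter is expected in this assay for this change. The expected value for compound 3 is 0.6 h within a range of 0.3 h to 1.2 h on this read-out.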

Compound 3, half-life: 0.767 h
Beside the measured number, compound 3's estimate is 1.3-fold (0.11 log units) below it; low and high end bracket the measured number.
By their numbers in this assay, from the lowest: compounds 2, 3 and 1 (each within the scatter of the next).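

In this assay, phenyl in place of propyl gives a 1.5-fold higher number from compound 2 to compound 3 (0.17 log units; within the scatter), and phenyl in place of methyl gives a 1.2-fold lower number from compound 1 to compound 3 (0.07 log units; within the scatter), both on the same saturated chain carbon. So this position carries a six-membered aromatic ring as well as a plain chain, with no step beyond the scatter among the three compounds. No data are available to explain this.

Still open, from the compounds shown here alone, is whether an amine or a carboxylic acid on this chain would shift the half-life beyond the scatter.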